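The compounds below may be only part of what the source reports. "The series", "measured", "known", "first", "only" and "open" are said of these compounds alone.

Measured compounds:
compound 1, `COc1cc(-c2cc(/C=C/C(=O)c3ccc(Cl)c(Cl)c3)[nH]n2)cc(OC)c1OC`: 6730 nM
compound 2, `COc1ccc(-c2cc(/C=C/C(=O)c3cc(OC)c(OC)c(OC)c3)[nH]n2)cc1OC`: 1660 nM

In a functional assay on RPMI-8226 cells (Homo sapiens) for inhibition, read by sulforhodamine B assay, with a stated time of 48 h (on this read-out higher numbers stand for weaker inhibition of growth and lower numbers for stronger inhibition of growth), compound 1 gives 6730 nM and stands highest of the two numbers shown; compound 2 gives 1660 nM, a lower number, and the gap between the two lies beyond the usual scatter. Compound 3, `COc1ccc(C(=O)/C=C/c2cc(-c3cc(OC)c(OC)c(OC)c3)n[nH]2)cc1OC`, has not yet been measured. It differs from compound 1 in one place: 3,4-dimethoxyphenyl in place of 3,4-dichlorophenyl on a carbonyl carbon. Among the measured compounds shown here, no step between measured compounds isolates this change, so what can be said rests on the two values shown. Compound 2, which also carries a methoxy-bearing aryl on the carbonyl carbon, gives 1660 nM, and on that basis the step of a 2.2-fold lower number from compound 1 to compound 3 (0.35 log units; beyond the scatter) is expected to be a moderate move toward stronger inhibition of growth, beyond the scatter but not large. Compound 3 is therefore estimated at 3000 nM in this assay, with a range from 1200 nM to 8000 nM.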

Compound 3, concentration for total growth inhibition: 1110 nM
The estimate for compound 3 lay 2.7-fold (0.43 log units) above the measured number; the measured number lies below the stated range.
By their numbers in this assay, from the lowest: compounds 3 and 2 (each within the scatter of the next); then compound 1.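

In this assay, among the compounds shown here, the earlier compounds offered no step that isolated the group on the carbonyl carbon, and this pair now does: 3,4-dimethoxyphenyl in place of 3,4-dichlorophenyl gives a 6.1-fold lower number from compound 1 to compound 3 (0.78 log units; beyond the scatter), a step beyond the scatter. This place is therefore not indifferent to the aryl group it carries, and with the rest of compound 1 unchanged, the exchange moves the read-out toward stronger inhibition of growth. Nothing available accounts for this shift.

The compounds shown leave open whether both methoxy groups are needed for the step or whether either alone would give it. They also leave open how this place would respond to an amine, a carboxylic acid or a longer ethoxy chain on the ring.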